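The compounds below may be only part of what the source reports. "The series", "measured", "known", "first", "only" and "open" are said of these compounds alone.

In a functional assay on SQ20B cells (Homo sapiens) for cytotoxicity, read by MTT assay, with a stated time of 72 h (a lower number here means a stronger inhibitor, a higher number a weaker inhibitor), the two measured members of the series read as follows:

compound 1, `O=C(c1ccccc1)c1cc2c(CN3CCC(N4CCCCC4)CC3)c(O)ccc2o1`: 17000 nM
compound 2, `Oc1ccc2oc(C(O)c3ccccc3)cc2c1CN1CCC(N2CCCCC2)CC1`: 13000 nM

Going by the values given here, only one step connects them: a 1.3-fold lower number from compound 1 to compound 2 (0.12 log units; within the scatter). Compound 2 therefore holds the lower of the two numbers, but the gap to compound 1 sits inside the usual scatter, so the two compounds cannot be ranked against each other on this evidence.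

Compound 3, `Oc1ccc2oc(-c3ccccc3)cc2c1CN1CCC(N2CCCCC2)CC1`, is the next member to be measured. Relative to compound 2 the change is phenyl in place of hydroxy(phenyl)methyl on an aromatic carbon. Among the compounds with values here, the only measured step that bears on this is the one from compound 1 to compound 2, which altered the same aromatic carbon by a comparable exchange of the group carrying the phenyl ring and moved this assay by an amount within the scatter. Within the data shown here, with no step so far moving this assay beyond the scatter, the step of no change at the digits printed from compound 2 to compound 3 (within the scatter) is expected to stay inside the scatter as well. Compound 3 is accordingly estimated at 13000 nM in this assay, with a range from 5000 nM to 35000 nM.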

Compound 3, half-maximal inhibitory concentration: 2800 nM
Beside the measured number, compound 3's estimate is 4.6-fold (0.67 log units) above it; measured number outside the range, below it.
By their numbers in this assay, from the lowest: compound 3; then compounds 2 and 1 (each within the scatter of the next).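

At the aromatic carbon next to the ring oxygen, this assay does respond to the group carried there: phenyl in place of hydroxy(phenyl)methyl gives a 4.6-fold lower number from compound 2 to compound 3 (0.67 log units; beyond the scatter) and phenyl in place of benzoyl gives a 6.1-fold lower number from compound 1 to compound 3 (0.78 log units; beyond the scatter) in the same direction, although the exchange between benzoyl and hydroxy(phenyl)methyl had left the number within the scatter. Within these three compounds, the two with a carbon linking the phenyl ring to the core therefore read alike, and only compound 3, with phenyl attached directly to the core, stands apart from both. Each step to compound 3 removes the linking carbon together with its oxygen, and no measurement on hand accounts for the lower number.

A benzyl group at this carbon would keep the linking carbon without its oxygen and so separate those two features of the change. From the compounds shown here alone, whether the aromatic ring is needed there at all remains open, as does the response to a methyl group or to a phenyl ring carrying a fluorine or methoxy substituent.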